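This account rests on a few compounds, and the source may have more. Where it says the series, first, only, none or still open, it means among the compounds named here.

Working notes on the series. Compound 2 `CCCCSC(=S)C1=C(Nc2ccc(Cl)cc2)CC(C)(C)CC1=O` is the reference point for the step under consideration. In a functional assay on PBMC cells (Homo sapiens) for inhibition, read by ELISA, with a stated time of 18 h (on this read-out higher numbers stand for weaker inhibition and lower numbers for stronger inhibition), compound 2 returns only a limit of the assay, > 20 ug/mL. Compound 1 `CCCCCCCCCCCSC(=S)C1=C(Nc2ccc(Cl)cc2Cl)CC(C)(C)CC1=O` is the other compound with a result. In this assay compound 1 also gives only a limit, > 20 ug/mL. The whole set so far rests on (the limit of > 20 ug/mL in this assay, at which 2 of the 2 values shown sit), so no numbered value exists against which a step could be measured, and nothing can be said of the order between compound 1 and compound 2.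

Compound 3 `CCCCCCCCCCCSC(=S)C1=C(Nc2ccc(Cl)cc2)CC(C)(C)CC1=O` differs from compound 2 by heptyl in place of hydrogen on a saturated chain carbon, four bonds along the chain from a sulfur. For the measured compounds named here, no step between measured compounds is available, and two limits offer no direction. The expectation for a step that the limit leaves unreadable from compound 2 to compound 3 is therefore no movement beyond the scatter, with compound 3 most likely again reporting a limit rather than a number. Compound 3 is estimated at 30 ug/mL, with a range from 10 ug/mL to 100 ug/mL.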

Compound 3, half-maximal inhibitory concentration: > 20 ug/mL
Compound 3: no number, only a limit; the forecaster's own chance of this, stated with the estimate: 80%; the middle value does not contradict the limit.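

In this assay, for the compounds shown here, compound 3 gives > 20 ug/mL as a limit and no number, so no step from compound 1 or compound 2 to compound 3 can be read. The compounds shown leave open whether the heptyl or the chloro difference alters inhibition in either direction.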